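The source may hold more compounds than are shown below. What is called first, only, known or untested is meant among the compounds shown, and "the series" means these compounds.

Working notes on a set of thiosemicarbazide-type compounds built on two cores, tested in a functional assay on MCF7 cells (Homo sapiens) for cytotoxicity, read by MTT assay, with a stated time of 72 h, tested at 1 uM; on this read-out higher numbers stand for more inhibition of growth at the one concentration tested and lower numbers for less inhibition of growth.

For the measured compounds named here, compound 1 `N/C(=N\NC(=S)N1CCCCCC1)c1ccccn1` gives 25.3% in this assay, the highest of the three numbers known so far. Compound 2 `N/C(=N\NC(=S)N1CCOCC1)c1ccccn1` gives 14.7% in this assay, a number beyond the scatter below that of compound 1. How the core of compound 1 differs from the core of compound 2 is not broken down here. Compound 3 `N/C(=N\NC(=S)N1CCOCC1)c1ccc(F)cn1` carries fluoro in place of hydrogen on an aromatic carbon relative to compound 2. In this assay compound 3 gives 12.4%. The step of a number 2.3 percentage points lower from compound 2 to compound 3 (within the scatter) is therefore small and within the scatter, so no word of order is warranted between compound 2 and compound 3.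

Compound 4 `N/C(=N\NC(=S)N1CCCCCC1)c1ccc(F)cn1`, not yet measured, stands to compound 1 as compound 3 stands to compound 2: the change is fluoro in place of hydrogen on an aromatic carbon, and the two place descriptions match word for word, so the change is the same one seen once already. On the core of compound 2 that change moved the number by a number 2.3 percentage points lower from compound 2 to compound 3 (within the scatter). Resting on that single precedent and on compound 1 at 25.3%, the step from compound 1 to compound 4 is expected to be a number 2.3 percentage points lower from compound 1 to compound 4 (within the scatter), within the scatter. Compound 4 is accordingly estimated at 23%, with a plausible range from 12% to 34%, pending the actual measurement.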

Compound 4, percent growth inhibition at one concentration: 16.8%
For compound 4 the middle estimate is 6.2 percentage points above the measured one, within the range that was stated.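

In this assay, fluoro in place of hydrogen on an aromatic carbon gives a number 8.5 percentage points lower from compound 1 to compound 4 (within the scatter), so on the core of compound 1 this step, like the earlier one, stays inside the usual scatter. Set side by side, the two steps do not differ by more than repeated measurements of this kind allow: the same change on two cores in this assay, a number 2.3 percentage points lower (within the scatter) from compound 2 to compound 3 and a number 8.5 percentage points lower (within the scatter) from compound 1 to compound 4, 6.2 percentage points apart, within the scatter of two such steps. This shows that, at the one concentration tested, the change can be carried between these two cores without producing a step that stands clear of the scatter; it does not show that the step is the same on both cores, or that the change moves the number at all, and two pairs of compounds are a thin base for any rule in this series.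

The compounds shown leave open whether another group on the same aromatic carbon, such as chloro, methoxy, an amine or a carboxylic acid, would give a step beyond the scatter on either core. For the compounds shown here, also open is how the same change reads at other concentrations, where a full dose-response comparison of each pair could separate a small step from no step.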